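The source may report more compounds than this note shows. Statements on the series, on what has been measured and on what is new or still open speak of the compounds shown alone.

Measured so far:
Compound 1, `COc1ccc(/C=C/C(=O)O)c(OCCC2(C)CCc3c(C)c(O)c(C)c(C)c3O2)c1`, in an in vitro functional assay on CHO cells for antagonist activity at prostaglandin E2 receptor EP3 subtype (Mus musculus) (on this read-out lower numbers stand for stronger inhibition and higher numbers for weaker inhibition), gives > 10000 nM.
Compound 2, `O=C(O)/C=C/c1ccc(Cn2ccnc2)cc1OCCCOc1ccccc1`, in this assay gives 3000 nM.

The value recorded for compound 1 is a limit of the assay and not a number (the limit of > 10000 nM in this assay, at which 1 of the 2 values shown sits). Compound 2 thus stands alone: it carries the only number shown in this assay, and no measured pair differing in a single place exists, so no step size within this set has been observed directly.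

Compound 3, `O=C(O)/C=C/c1ccc(Cn2ccnc2)cc1OCCc1ccc2ccccc2c1`, differs from compound 2 in one place: naphthalen-2-yl in place of phenoxymethyl on a saturated chain carbon, two bonds along the chain from an oxygen on an aromatic ring. Among the measured compounds shown here, since no measured pair tests this change, its effect in this assay is unknown, and any expectation rests on the single number of compound 2 alone. The step is expected to be a 3.0-fold lower number from compound 2 to compound 3 (0.48 log units; beyond the scatter), which would be a moderate gain in inhibition beyond the usual scatter. On that basis compound 3 is estimated at 1000 nM in this assay, with the range running from 200 nM to 5000 nM.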

Compound 3, half-maximal inhibitory concentration: 50 nM
Estimate against measurement, compound 3: 20-fold (1.30 log units) above; the whole stated range lies above it.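

In this assay, among the compounds shown here, the place on a saturated chain carbon, two bonds along the chain from an oxygen on an aromatic ring, proves highly sensitive to the group it carries: naphthalen-2-yl in place of phenoxymethyl gives a 60-fold lower number from compound 2 to compound 3 (1.78 log units; beyond the scatter), and this large step is the only single-place change that can be read in this set. The change removes phenoxymethyl, with its one six-membered aromatic ring of carbon only and one hydrogen-bond acceptor, and brings in two such rings and no hydrogen-bond acceptor, but this one pair cannot show which of these differences carries the step. Nothing in the data shown accounts for the size of the step.

The compounds shown leave open whether the chain oxygen or the second ring matters more, a question that a plain phenyl group or a naphthalen-1-yl group at this place would help to separate. They also leave open whether the step would hold with the carboxylic acid of the shared core replaced by an amide.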